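Notes on replacing chloro with bromo in the series

The compounds below may be only part of what the source reports. "The series", "measured", "known", "first", "only" and "open" are said of these compounds alone.

Compound 1 `CC1(C)[C@H]2CC[C@]1(C)N(Cc1cn(-c3ccccc3C#N)nn1)C(=O)C2`: 23300 nM
Compound 2 `CC1(C)[C@H]2CC[C@]1(C)N(Cc1cn(-c3ccccc3F)nn1)C(=O)C2`: 15100 nM
Compound 3 `CC1(C)[C@H]2CC[C@]1(C)N(Cc1cn(-c3cccc(Cl)c3)nn1)C(=O)C2`: 8840 nM

These values come from an ADME assay on MRC5 cells (Homo sapiens) for cytotoxicity, read by MTT assay, with a stated time of 24 h; a higher number here means that more compound is tolerated, a lower number that less compound is tolerated. Compound 3 stands at 8840 nM. Compound 4 `CC1(C)[C@H]2CC[C@]1(C)N(Cc1cn(-c3cccc(Br)c3)nn1)C(=O)C2` differs from it by bromo in place of chloro on an aromatic carbon, with bromo in place of chloro on an aromatic carbon. Among the compounds with values here, no measured step makes this exact change. The nearest steps alter the aromatic substituent: a 1.5-fold lower number from compound 1 to compound 2 (0.19 log units; within the scatter), then a 1.7-fold lower number from compound 2 to compound 3 (0.23 log units; within the scatter), and a 2.6-fold lower number from compound 1 to compound 3 (0.42 log units; beyond the scatter). Only the last lies beyond the scatter, and it is modest, so no clear step is expected in this assay and no direction is favoured. The expected result is a 1.1-fold lower number from compound 3 to compound 4 (0.04 log units; within the scatter). For compound 4 the estimated value is 8000 nM, with an expected range of 4500 nM to 14000 nM.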

Compound 4, half-maximal cytotoxic concentration: 38800 nM
Compound 4: middle estimate off by 4.9-fold (0.69 log units), on the low side; the whole stated range lies below it.
By their numbers in this assay, from the lowest: compounds 3, 2, 1 and 4 (each within the scatter of the next, the first and the last beyond it).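

In this assay, exchanging one halogen on this aromatic carbon is enough to shift the number beyond the scatter, with bromo in place of chloro giving a 4.4-fold higher number from compound 3 to compound 4 (0.64 log units; beyond the scatter) in this series. The 3-bromophenyl group also separates from the 2-fluorophenyl group, with a 2.6-fold higher number from compound 2 to compound 4 (0.41 log units; beyond the scatter) on the aromatic nitrogen. It does not separate from the 2-cyanophenyl group, with a 1.7-fold higher number from compound 1 to compound 4 (0.22 log units; within the scatter) as the comparison.

No measured evidence accounts for the difference between chloro and bromo here. As far as these compounds go, whether a methoxy group or an amine on the same aromatic carbon would follow bromo or chloro remains open.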